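This account rests on a few compounds, and the source may have more. Where it says the series, first, only, none or still open, it means among the compounds named here.

Of the compounds shown here, three built on one shared core have been measured in an assay on cells for inhibition of Voltage-dependent T-type calcium channel subunit alpha-1H (Homo sapiens), read by patch clamp, tested at 10 uM; on this read-out lower numbers stand for less inhibition and higher numbers for more inhibition at the one concentration tested (going by the name of the read-out). Compound 1 `CN(C)CCCCCSC1=Nc2ccccc2C(CC(=O)NCc2ccc(F)cc2)N1c1ccc(-c2ccccc2)cc1` gives 83.1%, compound 2 `CN(C)CCCCCSC1=Nc2ccccc2C(CC(=O)NCc2ccccc2)N1c1ccc(-c2ccc(F)cc2)cc1` gives 75.6%, and compound 3 `CN(C)CCCCCSC1=Nc2ccccc2C(CC(=O)NCc2ccccc2)N1c1ccccc1` gives 51.8%, the lowest of the three, with compound 2 nearest to it and compound 1 furthest. For the measured compounds named here, the only step measured in one place, a number 23.8 percentage points lower from compound 2 to compound 3 (beyond the scatter), concerns a different part of the molecule. Compound 4 `CN(C)CCCCCSC1=Nc2ccccc2C(CC(=O)NCc2ccc(F)cc2)N1c1ccccc1` differs from compound 3 by fluoro in place of hydrogen on an aromatic carbon. Going by the values given here, compound 1 and compound 2 each carry a fluoro, but in different places, so their values do not isolate this change, and no measured step bears on it directly. In this assay a step of a number 5.2 percentage points higher from compound 3 to compound 4 (within the scatter) is expected, within the scatter. Compound 4 is therefore estimated at 57%, between 40% and 73%.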

Compound 4, a percentage reported as inhibition, at one concentration (the size of the read-out at that concentration, not a potency): 7%
Compound 4: the middle estimate sits 50 percentage points above what was measured; measured number below the stated range.
By their numbers in this assay, from the lowest: compound 4; then compound 3; then compounds 2 and 1 (each within the scatter of the next).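

The change from benzyl to 4-fluorobenzyl, a single added atom, is no small one in this assay (a number 44.8 percentage points lower from compound 3 to compound 4 (beyond the scatter)). Hydrogen in place of phenyl, with the 4-fluorobenzyl group kept, also gives a large fall (a number 76.1 percentage points lower from compound 1 to compound 4 (beyond the scatter)). The same 4-fluorobenzyl group therefore goes with a high number in compound 1 and a low one in compound 4, so its outcome depends on what the rest of the molecule carries.

On these data alone, whether a chloro or a methoxy group in the fluoro's place would give the same fall stays open. Nothing available here explains the fall.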